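Methyl for Hydrogen on a Pair of Amides

The compounds below may be only part of what the source reports. "The series", "measured", "known", "first", "only" and "open" are said of these compounds alone.

Measured so far:
compound 1, `O=C(Nc1cccnc1)c1cncc(Br)c1`, gives 0.4% in an assay on V79 cells for inhibition of cytochrome P450 11B1, mitochondrial (Homo sapiens), tested at 500 nM; on this read-out lower numbers stand for less inhibition and higher numbers for more inhibition at the one concentration tested (going by the name of the read-out)
compound 2, `O=C(Nc1cccnc1)c1ccccc1`, gives 2% in this assay

Both compounds share an amide core, and in this assay compound 2 and compound 1 give numbers that lie within the usual scatter of each other, so the inhibition in this assay is level between them at the concentration tested. Compound 3, `Cc1ccc(C(=O)Nc2cccnc2)cc1`, has not been measured. It differs from compound 2 in one place: methyl in place of hydrogen on an aromatic carbon. For the measured compounds named here, nothing among the measured compounds shows what this change does here, since no pair differing in one place has been measured. With compound 2 and compound 1 both near the floor of the read-out, the expected step from compound 2 to compound 3 is a number 1 percentage points higher from compound 2 to compound 3 (within the scatter), a change that should stay within the scatter rather than beyond it. Compound 3 is therefore estimated at 3%, in the range 0% to 15%.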

Compound 3, a percentage reported as inhibition, at one concentration (the size of the read-out at that concentration, not a potency): 0%
Estimate against measurement, compound 3: 3 percentage points above, and the stated range covers the measured number.
By their numbers in this assay, from the lowest: compounds 3, 1 and 2 (each within the scatter of the next).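

In this assay the first pair differing in one place shows a number 2 percentage points lower from compound 2 to compound 3 (within the scatter) and so methyl in place of hydrogen, at this position para to a group of 9 heavy atoms, brings no inhibition that can be told from the scatter. Compound 2 already sits near the bottom of the read-out, so this pair can show that the methyl adds nothing at this concentration, but it leaves little room to show any loss. Nothing measured on hand explains this outcome.

On these data alone, whether an amine, a carboxylic acid or a longer chain such as propyl at the same position would lift the number remains open. As far as these compounds go, it is equally open whether methyl at another place on this ring would behave the same way.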